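The source may report more compounds than this note shows. Statements on the series, on what has been measured and on what is new or still open speak of the compounds shown alone.

Measured so far:
compound 1, `COc1cc(/C=C/C(=O)c2sc(Nc3ccc(C)cc3)nc2C)cc(OC)c1OC` — > 25000 nM
compound 2, `Cc1ccc(Nc2nc(C)c(C(=O)/C=C/c3ccccc3)s2)cc1` — > 25000 nM

Compound 1 is one of two compounds tested in a functional assay on BGC-823 cells (Homo sapiens) for cytotoxicity, read by MTT assay; a higher number here means a weaker inhibitor, a lower number a stronger inhibitor. In this assay compound 1 gives only > 25000 nM, which is a limit of the assay rather than a measured number. Compound 2 likewise gives > 25000 nM in this assay, again a limit and not a number. Where compound 1 stands is therefore set by the limit of > 25000 nM in this assay, at which 2 of the 2 values shown sit, with nothing pointing to a measurable potency.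

The next compound, compound 3 with the structure `COc1cc(/C=C/C(=O)c2sc(Nc3cccc(Cl)c3)nc2C)cc(OC)c1OC`, has not yet been measured. It differs from compound 1 in one place: 3-chlorophenyl in place of 4-methylphenyl on a nitrogen on an aromatic ring. For the measured compounds named here, no step between measured compounds is known, so there is no basis for expecting a shift beyond the usual scatter, and the expected step is a number no higher from compound 1 to compound 3 (the limit leaves the size open). Compound 3 is thus estimated at 25000 nM, within a range of 8000 nM to 60000 nM, most likely reported again as a limit.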

Compound 3, half-maximal inhibitory concentration: 11600 nM
Beside the measured number, compound 3's estimate is 2.2-fold (0.33 log units) above it; measured number inside the range.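

In this assay, 3-chlorophenyl in place of 4-methylphenyl on a nitrogen on an aromatic ring gives an at least 2.1-fold lower number from compound 1 to compound 3 (0.33 log units; beyond the scatter), so a change at this one place, with the rest of the core of compound 1 kept, is enough to move the read-out beyond the scatter. Going by these compounds, the true size of the step stays unknown, and the figure for it is only a lower bound. Compound 3 is the only compound shown that gives a number and not a limit: the limit of > 25000 nM in this assay, at which 2 of the 3 values shown sit.

The two groups differ both in the atom they carry and in where it sits, so the compounds shown do not say which of these matters; 4-chlorophenyl or 3-methylphenyl would tell them apart. On these data alone, how an amine or a carboxylic acid in place of the chlorine would read also stays open.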